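Working notes: cytotoxicity estimate for compound 3

This account rests on a few compounds, and the source may have more. Where it says the series, first, only, none or still open, it means among the compounds named here.

compound 1 `COc1ccc2[nH]c(C(=O)N3CC(=O)N(Cc4ccccc4)[C@@H](CN4CCC(C)CC4)C3)cc2c1` — an ADME assay on Vero cells (Chlorocebus sabaeus) for cytotoxicity, with a stated time of 7 days; on this read-out higher numbers stand for lower toxicity in this test and lower numbers for higher toxicity in this test: > 30000 nM
compound 2 `O=C(c1cc2cc(C3CC3)ccc2[nH]1)N1CC(=O)N(Cc2ccccc2)[C@@H](CN2CCN(Cc3ccccc3)CC2)C1` — this assay: 5500 nM

Compound 1 carries a 4-methylpiperidin-1-yl group on a saturated chain carbon bound to a saturated ring carbon. In this assay compound 1 reports only a limit, > 30000 nM, so it stands at the limit of > 30000 nM in this assay, at which 1 of the 2 values shown sits, and no number is known for it. In this assay compound 2 gives 5500 nM. Going by the values given here, compound 1 and compound 2 differ in more than one place, so no single step joins them; their two values show only that one reaches the limit and the other gives a number.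

Compound 3 `COc1ccc2[nH]c(C(=O)N3CC(=O)N(Cc4ccccc4)[C@@H](CN4CC5(CCC5)C4)C3)cc2c1` is not yet measured and differs from compound 1 in one place: a group of 7 heavy atoms (6 carbon, 1 nitrogen; one four-membered non-aromatic ring of carbon only, one four-membered non-aromatic ring with 1 hetero atom) in place of a group of 7 heavy atoms (6 carbon, 1 nitrogen; one six-membered non-aromatic ring with 1 hetero atom), on a saturated chain carbon bound to a saturated ring carbon. Among the compounds with values here, no measured pair covers this change. In this assay the step expected is a number no higher from compound 1 to compound 3 (the limit leaves the size open), none beyond the scatter in either direction. Compound 3 is expected to give 30000 nM, with a range of 12000 nM to 100000 nM, and most probably again only a limit.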

Compound 3, half-maximal cytotoxic concentration: 52700 nM
Compound 3: middle estimate off by 1.8-fold (0.24 log units), on the low side; the measured number falls inside the stated range.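

No step from compound 1 to compound 3 can be read in this assay, because compound 1 stands at a limit and not at a number: the limit of > 30000 nM in this assay, at which 1 of the 3 values shown sits.

In this assay the compounds shown leave open how large the change is when the group of compound 3 replaces 4-methylpiperidin-1-yl.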